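This account rests on a few compounds, and the source may have more. Where it says the series, first, only, none or still open, it means among the compounds named here.

Measured compounds in this series:
- compound 1, `CCCC(=O)Nc1c(C(O)(C(F)(F)F)C(F)(F)F)ccc2ccccc12`: 131 nM
- compound 2, `CCC(C)C(=O)Nc1c(C(O)(C(F)(F)F)C(F)(F)F)ccc2ccccc12`: 177000 nM
- compound 3, `O=C(Nc1c(C(O)(C(F)(F)F)C(F)(F)F)ccc2ccccc12)C1CCCC1`: 495 nM

All three share one core and differ only in the group on the carbonyl carbon of the amide. In an assay on LtK cells with ATP-sensitive inward rectifier potassium channel 11 (Homo sapiens) as the target (on this read-out higher numbers stand for an effect only at larger amounts of compound and lower numbers for an effect already at smaller amounts), compound 2 stands highest of the three numbers: the step of a 1400-fold higher number from compound 1 to compound 2 (3.13 log units; beyond the scatter) is the largest in the set, and a 360-fold lower number from compound 2 to compound 3 (2.55 log units; beyond the scatter) brings the number back most of the way. Compound 1 and compound 3 lie closer together, a 3.8-fold higher number from compound 1 to compound 3 (0.58 log units; beyond the scatter).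

The next compound is compound 4, `Cc1ccccc1C(=O)Nc1c(C(O)(C(F)(F)F)C(F)(F)F)ccc2ccccc12`. The change from compound 2 is 2-methylphenyl in place of sec-butyl on a carbonyl carbon. Among the compounds with values here, two measured steps bear on it. The large step from compound 2 to compound 3 shows that replacing sec-butyl on the carbonyl carbon by a ring group lowers the number strongly; the step from compound 1 to compound 3 shows that a ring group on that carbon does not reach the number of compound 1. Within the data shown here, no measured compound carries an aromatic ring at this place, so the size of the effect of 2-methylphenyl is uncertain. A lowering from compound 2 of roughly the order of a 120-fold lower number from compound 2 to compound 4 (2.07 log units; beyond the scatter) is expected in this assay, with a wide range. For compound 4 the estimate in this assay is 1500 nM, expected between 150 nM and 20000 nM.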

Compound 4, half-maximal effective concentration: 5550 nM
Beside the measured number, compound 4's estimate is 3.7-fold (0.57 log units) below it; low and high end bracket the measured number.
By their numbers in this assay, from the lowest: compound 1; then compound 3; then compound 4; then compound 2.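

In this assay, within the data shown here, 2-methylphenyl is the first aromatic ring on this carbonyl carbon, and replacing sec-butyl with it gives a 32-fold lower number from compound 2 to compound 4 (1.50 log units; beyond the scatter), so the lowering seen on leaving sec-butyl is not confined to cyclopentyl. The two ring groups are not equivalent at this place: exchanging cyclopentyl for 2-methylphenyl gives an 11-fold higher number from compound 3 to compound 4 (1.05 log units; beyond the scatter), and exchanging propyl for 2-methylphenyl gives a 42-fold higher number from compound 1 to compound 4 (1.63 log units; beyond the scatter), which leaves propyl with the lowest number of the four groups. Sec-butyl still has the highest number, so among these compounds the extreme rise belongs to that one group and to neither ring group.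

No available measurement accounts for these differences between the groups. Also open, as far as these compounds go, is how much of the number of compound 4 depends on its methyl group, and whether plain phenyl, a longer straight chain such as pentyl, or a chain carrying an amine on this carbonyl carbon would fall nearer to compound 1 or to compound 2.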